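Compound 4 and a record made only of limits

The source may hold more compounds than are shown below. What is called first, only, known or untested is meant among the compounds shown, and "the series" means these compounds.

Compound 1 `COc1ccc(-c2nc3c(c(C)nn3-c3ccccc3)c(-c3ccccc3O)c2C#N)cc1`: > 23000 nM (a limit)
Compound 2 `Cc1nn(-c2ccccc2)c2nc(-c3ccccc3)c(C#N)c(-c3ccccc3O)c12`: > 23000 nM (a limit)
Compound 3 `CCc1ccc(-c2nc3c(c(C)nn3-c3ccccc3)c(-c3ccccc3F)c2C#N)cc1`: > 20000 nM (a limit)

All three compounds were tested in an ADME assay on BJ cells (Homo sapiens) for cytotoxicity, with a stated time of 72 h (a lower number here means that less compound is needed, a higher number that more compound is needed for the effect), and no reading so far is an actual number. Compound 3 stands at the limit of > 20000 nM in this assay, at which 1 of the 3 values shown sits. Compound 1 and compound 2 stand at the limit of > 23000 nM in this assay, at which 2 of the 3 values shown sit.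

Compound 4 `CCc1ccc(-c2nc3c(c(C)nn3-c3ccccc3)c(-c3cccc(O)c3)c2C#N)cc1` differs from compound 3 in one place, where 3-hydroxyphenyl takes the place of 2-fluorophenyl (3-hydroxyphenyl in place of 2-fluorophenyl on an aromatic carbon). The swap sits on an aromatic carbon, ortho to a cyano group, meta to a 4-ethylphenyl group and opposite the ring nitrogen.

For the measured compounds named here, the only measured step is a step that the two limits leave unreadable from compound 1 to compound 2. It concerns a different place in the molecule, so it gives no size to carry over. The nearest guide is a single compound. Compound 2, which also carries a hydroxyphenyl group, gives > 23000 nM, again a limit. No step beyond the usual scatter is therefore expected, and another limit is the likeliest report from this assay. The estimated change is a number no higher from compound 3 to compound 4 (the limit leaves the size open). For compound 4 the expected value is 20000 nM, with an estimated range from 8000 nM to 40000 nM.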

Compound 4, half-maximal effective concentration: > 20000 nM
Compound 4: a limit, no number; the forecaster's own chance of this, stated with the estimate: 80%; the middle value lies on the limit itself.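

Compound 3 and compound 4 each give only a limit in this assay, not a number, so no step can be read between them, and putting 3-hydroxyphenyl in place of 2-fluorophenyl has no size here. The compounds shown leave open what concentration of any of them produces the effect, and whether these group changes shift it.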